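The source may report more compounds than this note shows. Statements on the series, on what has been measured and on what is new or still open speak of the compounds shown alone.

The measured compounds in an ADME assay on the whole organism with Oryza sativa as the target, tested at 0.1 uM; a lower number here means a stronger effect, a higher number a weaker effect of the compound at the concentration tested:

compound 1, `Cc1ccccc1NC(=O)N[C@@H](C)c1ccccc1`: 100%
compound 2, `C[C@H](NC(=O)Nc1ccccc1F)c1ccccc1`: 98%
compound 3, `C[C@H](NC(=O)Nc1ccc(F)cc1F)c1ccccc1`: 101%

All three numbers lie close together. Compound 3 is separated from compound 1 and from compound 2 by differences that fall within the usual scatter, so on these numbers compound 3 stands alongside the other two rather than apart from them.

Compound 4, `Cc1cc(F)ccc1NC(=O)N[C@@H](C)c1ccccc1`, has not been measured in this assay. It differs from compound 3 by one change: methyl in place of fluoro on an aromatic carbon. For the measured compounds named here, two measured steps bear on this change. The step of a number 2 percentage points lower from compound 1 to compound 2 (within the scatter) is the reverse of the same exchange and was within the scatter. The step of a number 3 percentage points higher from compound 2 to compound 3 (within the scatter) concerns the fluoro group on the same ring and was also within the scatter. Neither exchange of a small aromatic substituent moved the read-out beyond the scatter, so no step beyond the scatter is expected for compound 4 in this assay; the expected step is a number 1 percentage points lower from compound 3 to compound 4 (within the scatter). Compound 4 is therefore estimated at 100%, within a range from 92% to 106%.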

Compound 4, a percentage reported as activity, at one concentration (the size of the read-out at that concentration, not a potency): 99%
Compound 4: middle estimate off by 1 percentage points, on the high side; measured number inside the range.
By their numbers in this assay, from the lowest: compounds 2, 4, 1 and 3 (each within the scatter of the next).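

In this assay, methyl in place of fluoro on an aromatic carbon ortho to a large group gives a number 2 percentage points lower from compound 3 to compound 4 (within the scatter), and fluoro in place of hydrogen gives a number 1 percentage points lower from compound 1 to compound 4 (within the scatter). The exchange of methyl and fluoro at this position now stands on a second core, with a fluoro group meta to the site, and it reads alike on both: the same change on two cores in this assay, a number 2 percentage points lower (within the scatter) from compound 1 to compound 2 and a number 2 percentage points higher (within the scatter) from compound 4 to compound 3, 4 percentage points apart, within the scatter of two such steps Fluoro in place of hydrogen also reads alike whether the core carries methyl or fluoro at this position: the same change on two cores in this assay, a number 3 percentage points higher (within the scatter) from compound 2 to compound 3 and a number 1 percentage points lower (within the scatter) from compound 1 to compound 4, 4 percentage points apart, within the scatter of two such steps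

On these data alone, only methyl, fluoro and hydrogen appear in these exchanges, so it remains open whether an amine, a carboxylic acid or a longer chain on this aromatic carbon would move the read-out beyond the scatter in this assay. As far as these compounds go, it also remains open whether these compounds would separate at a higher concentration.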